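A few compounds are considered here, and "the series" means these few. Any claim that something is new, unique, unknown or untested is made for them only; others in the source may bear on it.

Measured so far:
compound 1, `CCCCCCCCNc1nccnc1C(=O)NCc1ccccc1`: > 100000 nM
compound 2, `CCCCNc1cnc(C(=O)NCc2ccccc2)cn1`: > 100000 nM

In an ADME assay on Vero cells (Chlorocebus sabaeus) for cytotoxicity, read by microscopy, with a stated time of 6 days (a lower number here means that less compound is tolerated, a higher number that more compound is tolerated), compound 1 gives > 100000 nM, which is a limit of the assay rather than a measured number. In this assay compound 2 gives > 100000 nM, likewise a limit. Compound 1 therefore stands at the limit of > 100000 nM in this assay, at which 2 of the 2 values shown sit, and with no value anywhere else among the compounds shown, no step between measured compounds can be read off.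

Compound 3, `CCCCCCCNc1nccnc1C(=O)NCc1ccccc1`, has yet to be measured in this assay. It differs from compound 1 in one place: hydrogen in place of methyl on a saturated chain carbon, seven bonds along the chain from a nitrogen on an aromatic ring. Because compound 1 sits at the limit of > 100000 nM in this assay, at which 2 of the 2 values shown sit, together with every other value shown, there is nothing to suggest movement. The expected step is a number no higher from compound 1 to compound 3 (the limit leaves the size open), none beyond the scatter. Compound 3 is thus expected to give 100000 nM, somewhere between 40000 nM and 250000 nM, and most likely to be reported only as a limit once more.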

Compound 3, minimum cytotoxic concentration: > 100000 nM
Compound 3 was reported as a limit; the forecaster's own chance of this, stated with the estimate: 80%; the middle value sits exactly at the limit.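

No step can be read from compound 1 to compound 3, since both values are limits of the assay rather than measured numbers: the limit of > 100000 nM in this assay, at which 3 of the 3 values shown sit.

The compounds shown leave open at what concentration any of them becomes toxic to the cells in this assay, and whether hydrogen in place of methyl alters that concentration.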